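This account rests on a few compounds, and the source may have more. Where it says the series, first, only, none or still open, it means among the compounds named here.

Measured compounds:
- compound 1, `CC(C)n1cc(-c2cc(C(O)(C(F)(F)F)C(F)(F)F)cnc2N2CCN(S(=O)(=O)c3ccc(N)nc3)CC2)cn1`: 198 mL.min-1.g-1
- compound 2, `CC(C)(C)n1cc(-c2cc(C(O)(C(F)(F)F)C(F)(F)F)cnc2N2CCN(S(=O)(=O)c3ccc(N)nc3)CC2)cn1`: 459 mL.min-1.g-1
- compound 3, `Nc1ccc(S(=O)(=O)N2CCN(c3ncc(C(O)(C(F)(F)F)C(F)(F)F)cc3-c3cccnc3)CC2)cn1`: 20 mL.min-1.g-1

These three compounds share a core and differ only in the group on one aromatic carbon. In an ADME assay (liver) for metabolic stability, with Liver microsome (Rattus norvegicus) as the target, using microsomes and NADPH, with a stated time of 30 min, tested at 1 uM (a higher number here means faster removal of the compound, a lower number slower removal), compound 1 stands second highest of the three numbers; its nearest neighbour is compound 2, reached by a 2.3-fold higher number from compound 1 to compound 2 (0.37 log units; beyond the scatter), and its furthest is compound 3, reached by a 9.9-fold lower number from compound 1 to compound 3 (1.00 log units; beyond the scatter).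

Compound 4, `Nc1ccc(S(=O)(=O)N2CCN(c3ncc(C(O)(C(F)(F)F)C(F)(F)F)cc3-c3ccc4c(c3)CC(=O)N4)CC2)cn1`, is not yet measured. It differs from compound 1 in this way: a group of 10 heavy atoms (8 carbon, 1 nitrogen, 1 oxygen; one five-membered non-aromatic ring with 1 hetero atom, one six-membered aromatic ring of carbon only) in place of a group of 8 heavy atoms (6 carbon, 2 nitrogen; one five-membered aromatic ring with 2 hetero atoms), on an aromatic carbon.

For the measured compounds named here, the step that bears most on this change is the one from compound 1 to compound 3, where the 1-isopropyl-1H-pyrazol-4-yl group was also exchanged for a group without a saturated chain carbon, giving a 9.9-fold lower number from compound 1 to compound 3 (1.00 log units; beyond the scatter). The step to compound 2 points the other way: adding a methyl on the saturated chain carbon gave a 2.3-fold higher number from compound 1 to compound 2 (0.37 log units; beyond the scatter). Since compound 4, like compound 3, loses the isopropyl-bearing pyrazole, a lower number in this assay is expected, though the entering group is larger than pyridin-3-yl, so the drop is estimated to be somewhat smaller: a 4.4-fold lower number from compound 1 to compound 4 (0.64 log units; beyond the scatter). Compound 4 is therefore expected to give about 45 mL.min-1.g-1, with a likely range from 15 mL.min-1.g-1 to 130 mL.min-1.g-1.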

Compound 4, intrinsic clearance in microsomes: 119 mL.min-1.g-1
Compound 4: middle estimate off by 2.6-fold (0.42 log units), on the low side, within the range that was stated.
By their numbers in this assay, from the lowest: compound 3; then compounds 4 and 1 (each within the scatter of the next); then compound 2.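

In this assay at this aromatic carbon, losing the 1-isopropyl-1H-pyrazol-4-yl group does not by itself fix the number: exchanging it for the new group gives a 1.7-fold lower number from compound 1 to compound 4 (0.22 log units; within the scatter) and leaves no readable difference. The entering group, with its five-membered non-aromatic ring and its six-membered aromatic ring of carbon only, does stand apart from the other two groups, with a 6.0-fold higher number from compound 3 to compound 4 (0.77 log units; beyond the scatter) and a 3.9-fold lower number from compound 2 to compound 4 (0.59 log units; beyond the scatter) in those comparisons. The low number of compound 3 therefore goes with pyridin-3-yl in this set and does not follow from every replacement of the pyrazole.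

From the compounds shown here alone, whether a plain phenyl group or a morpholine at this aromatic carbon would give a number nearer that of compound 3 or that of compound 2 stays open. No measurement shown here explains the differences between these groups.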